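A Second Bromo on the Aromatic Ring

The compounds below may be only part of what the source reports. "The series", "measured", "known", "first", "only" and "open" are said of these compounds alone.

Of the compounds shown here, three that share one core have been measured in a functional assay on the whole organism for positive allosteric modulation, with Mus musculus as the target; on this read-out higher numbers stand for an effect only at larger amounts of compound and lower numbers for an effect already at smaller amounts. Compound 1 `CCC(=O)N(c1cccc(C)c1)C1CCCC1N(C)C`, which carries a methyl group on the aromatic ring, gives 3 mg/kg; 3 mg/kg (2 entries) in both of its entries. Compound 2 `CCC(=O)N(c1cccc(F)c1)C1CCCC1N(C)C` has fluoro in that place and gives 0.4 mg/kg. Compound 3 `CCC(=O)N(c1cccc(Br)c1)C1CCCC1N(C)C` has bromo there and gives 0.1 mg/kg, the lowest number of the three.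

The next structure is compound 4 `CCC(=O)N(c1ccc(Br)c(Br)c1)C1CCCC1N(C)C`, which keeps that bromo and gains a second one. The change is bromo in place of hydrogen on an aromatic carbon, or in short, bromo in place of hydrogen on an aromatic carbon.

Going by the values given here, only one measured step bears on this change: a 4.0-fold lower number from compound 2 to compound 3 (0.60 log units; beyond the scatter). That step is modest but beyond the scatter, and it points toward a lower number with bromo on the ring. It is only an indirect guide, since it swaps one group for another instead of adding a group at a new place. No measurement here shows what a second group on the ring does.

The estimated change is a 1.3-fold lower number from compound 3 to compound 4 (0.10 log units; within the scatter), a slight lean toward a lower number that is not expected to stand beyond the scatter. For compound 4 the expected value is 0.08 mg/kg, with an estimated range from 0.02 mg/kg to 0.4 mg/kg.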

Compound 4, dose for half-maximal effect: 0.1 mg/kg
For compound 4 the middle estimate is 1.3-fold (0.10 log units) below the measured one, within the range that was stated.
By their numbers in this assay, from the lowest: compounds 3 and 4 (each within the scatter of the next); then compound 2.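

In this assay, adding a second bromo on an aromatic carbon, ortho to a bromo group and para to a large group, gives no change at the digits printed from compound 3 to compound 4 (within the scatter). The earlier compounds shown here differ only in which single group sits at one place on the ring, so they could not show what happens when a ring carbon that carried hydrogen takes on a new group. Here that new place accepts a bromo without moving the dose for half-maximal effect beyond the usual scatter of repeated measurements, so on this read-out compound 4 cannot be told apart from compound 3, and nothing shown here gives a reason for this result.

The compounds shown leave open whether this place would tolerate other groups in the same way, such as a methoxy group, an amine or a carboxylic acid, since bromo is the only group seen there. They also leave open how a bromo at this place would behave with the other bromo replaced by fluoro or methyl, which would show whether the two places act independently of each other.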